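Working notes on the thiophen-2-yl branch

A few compounds are considered here, and "the series" means these few. Any claim that something is new, unique, unknown or untested is made for them only; others in the source may bear on it.

Compound 1 `C#Cc1cn([C@@H]2O[C@H](CO)[C@@H](O)[C@H]2O)c2ncnc(C)c12` and compound 2 `Cc1ncnc2c1c(-c1cccs1)cn2[C@@H]1O[C@H](CO)[C@@H](O)[C@H]1O` both reach only the limit of a functional assay on HCT-116 cells (Homo sapiens), read by MTT assay, with a stated time of 72 h; a lower number here means a stronger inhibitor, a higher number a weaker inhibitor. In this assay compound 1 gives a limit, > 20000 nM. Compound 2 likewise gives only a limit, > 20000 nM. Within the data shown here, compound 3 `Cc1ncnc2c1c(-c1ccsc1)cn2[C@@H]1O[C@H](CO)[C@@H](O)[C@H]1O` is the single numbered value, 460 nM. The step is an at least 43-fold lower number from compound 1 to compound 3 (1.63 log units; beyond the scatter) and an at least 43-fold lower number from compound 2 to compound 3 (1.63 log units; beyond the scatter), while a step that the two limits leave unreadable from compound 1 to compound 2. Compound 2 therefore stands at the limit (the limit of > 20000 nM in this assay, at which 2 of the 3 values shown sit). Compound 4 `CSc1ncnc2c1c(-c1cccs1)cn2[C@@H]1O[C@H](CO)[C@@H](O)[C@H]1O` differs from compound 2 by methylsulfanyl in place of methyl on an aromatic carbon. Among the measured compounds shown here, no measured step touches this change; compound 4 keeps the thiophen-2-yl of compound 2, and the only change seen to help, thiophen-3-yl, is absent. The step expected is a step that the limit leaves unreadable from compound 2 to compound 4, most likely ending again at a limit. Compound 4 is estimated at 25000 nM, between 5000 nM and 100000 nM.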

Compound 4, half-maximal inhibitory concentration: > 20000 nM
Compound 4: only a limit was reported; the forecaster's own chance of this, stated with the estimate: 70%; the middle value lies beyond the limit too.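

Compound 2 and compound 4 both stand only at a limit in this assay, so the step between them cannot be read. Still open, on these data alone, is how methylsulfanyl in place of methyl behaves alongside the thiophen-3-yl of compound 3.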